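Removing a benzyl group from a protected sugar antiproliferative

The source may report more compounds than this note shows. Statements on the series, on what has been measured and on what is new or still open speak of the compounds shown alone.

Measured compounds:
compound 1 `CC(=O)OC[C@@H]1O[C@H](COCc2ccccc2)[C@@H](OCc2ccccc2)[C@H](OCc2ccccc2)[C@H]1OC(C)=O` — "not active" (no number reported)
compound 2 `OC[C@H]1O[C@@H](Cc2ccccc2)[C@H](O)[C@@H](OCc2ccccc2)[C@@H]1OCc1ccccc1` — 20200 nM
compound 3 `OC[C@H]1O[C@@H](Cc2ccccc2)[C@H](O)[C@@H](OCc2ccccc2)[C@@H]1O` — "not active" (no number reported)

For the measured compounds named here, in a functional assay on HL-60 cells (Homo sapiens) for antiproliferative activity, read by MTT assay (on this read-out higher numbers stand for weaker inhibition and lower numbers for stronger inhibition), compound 2 is the only compound with a number; compound 1 and compound 3 gave no number and were reported as not active. Compound 4 `OC[C@H]1O[C@@H](Cc2ccccc2)[C@H](O)[C@@H](O)[C@@H]1OCc1ccccc1` is not yet measured. It differs from compound 2 in one place: hydrogen in place of benzyl on an oxygen on a saturated carbon. Going by the values given here, no measured pair tells how such a change acts here, and the only related compound with fewer benzyl groups, compound 3, returned no number. The step of a 2.5-fold higher number from compound 2 to compound 4 (0.39 log units; beyond the scatter) is therefore expected to go toward weaker inhibition, beyond the scatter. For compound 4 the estimate is 50000 nM, within 20000 nM to 150000 nM, with a real chance that only a limit is reported.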

Compound 4, half-maximal inhibitory concentration: "not active" (no number reported)
Compound 4: no number reported; the estimate stays without a comparison.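

For the compounds shown here, compound 4 was reported as not active, without a number, so no step from compound 2 to compound 4 can be read. The compounds shown leave open how large the change on losing this benzyl group is. No measured evidence bears on this result.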